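Aryl amine variation on a shared core

The source may report more compounds than this note shows. Statements on the series, on what has been measured and on what is new or still open speak of the compounds shown alone.

Three compounds share one core and differ only in the aryl group on the amine nitrogen. Compound 1 `O=C1C=C(Nc2ccccc2)C(=O)c2c1nc1n2[C@H]2OC[C@@H](O)[C@H]2OC1` carries a plain phenyl; compound 2 `CCOc1ccccc1NC1=CC(=O)c2c(nc3n2[C@H]2OC[C@@H](O)[C@H]2OC3)C1=O` a 2-ethoxyphenyl; compound 3 `CCOc1ccc(NC2=CC(=O)c3nc4n(c3C2=O)[C@H]2OC[C@@H](O)[C@H]2OC4)cc1` a 4-ethoxyphenyl. In a functional assay on ECa-109 cells for inhibition, with ECa-109 cell line (Homo sapiens) as the target, read by sulforhodamine B assay (a lower number here means a stronger inhibitor, a higher number a weaker inhibitor), compound 1 gives 4970 nM, compound 2 gives 4320 nM and compound 3 gives 3210 nM. Going by the values given here, the one step measured between compounds that differ in a single place is a 1.5-fold lower number from compound 1 to compound 3 (0.19 log units; within the scatter). Compound 2 sits in the middle of the three numbers, within the scatter of compound 1 on one side and of compound 3 on the other, so the three aryl groups tried so far cannot be told apart in this assay.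

The next compound, compound 4 `CCc1ccc(NC2=CC(=O)c3c(nc4n3[C@H]3OC[C@@H](O)[C@H]3OC4)C2=O)cc1`, differs from compound 2 as follows: 4-ethylphenyl in place of 2-ethoxyphenyl on an amine nitrogen. Among the compounds with values here, no measured step covers an ethyl group or the loss of the ether oxygen, so the only guide is that moving an ethoxy group on the ring, or removing it, has left the number within the scatter. The expected step is therefore a 1.1-fold lower number from compound 2 to compound 4 (0.03 log units; within the scatter), essentially none beyond the scatter. Compound 4 is expected to give about 4000 nM, with a range of 2000 nM to 8000 nM.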

Compound 4, half-maximal inhibitory concentration: > 4000 nM
Compound 4 was reported as a limit; the forecaster's own chance of this, stated with the estimate: 5%; the middle value sits exactly at the limit.
By their numbers in this assay, from the lowest: compounds 3, 2 and 1 (each within the scatter of the next).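

Compound 4 is reported in this assay as a limit, > 4000 nM. No new step can be read from compound 2 to compound 4. The compounds shown leave open how the 4-ethylphenyl group compares with the 2-ethoxyphenyl group on the amine nitrogen, and whether any aryl group on the shared core moves the number in this assay beyond the scatter.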